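The source may hold more compounds than are shown below. What is called first, only, known or untested is meant among the compounds shown, and "the series" means these compounds.

Compound 1 `CCCn1c(=O)[nH]c2nc(-c3ccc(S(=O)(=O)N4CCN(c5ccc(F)cc5)CC4)cc3)[nH]c2c1=O` — > 1000 nM
Compound 2 `CCCn1c(=O)[nH]c2nc(-c3ccc(S(=O)(=O)N4CCN(c5ccc(Br)cc5)CC4)cc3)[nH]c2c1=O` — > 1000 nM

In an assay on CHO cells for displacement of a labelled ligand from adenosine receptor A3 (Homo sapiens), read by scintillation counting, with a stated time of 45 min, in the presence of a further agent that is not named here (a lower number here means a stronger inhibitor, a higher number a weaker inhibitor), compound 1 gives > 1000 nM, a limit of the assay. Compound 2 gives > 1000 nM, likewise a limit. The step that the two limits leave unreadable from compound 1 to compound 2 is therefore unreadable, because both values sit at the limit of > 1000 nM in this assay, at which 2 of the 2 values shown sit. Compound 2 thus stands only at a limit, with no number of its own.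

Compound 3 `CCCn1c(=O)[nH]c2nc(-c3ccc(S(=O)(=O)N4CCN(Cc5cccc(C)c5)CC4)cc3)[nH]c2c1=O` differs from compound 2 by 3-methylbenzyl in place of 4-bromophenyl on an amine nitrogen in a ring. No measured step bears on this change, so neither its size nor its direction can be anticipated from the shown values. Compound 3 is expected near 2000 nM, within 300 nM to 10000 nM. This estimate implies an expected step that the limit leaves unreadable from compound 2 to compound 3.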

Compound 3, inhibition constant: > 1000 nM
Compound 3: only a limit was reported; the forecaster's own chance of this, stated with the estimate: 60%; the middle value does not contradict the limit.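

No step can be read from compound 1 or compound 2 to compound 3 in this assay, since all three values are limits: the limit of > 1000 nM in this assay, at which 3 of the 3 values shown sit. The compounds shown leave open whether any of these groups on the amine nitrogen changes the inhibition constant.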